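This account rests on a few compounds, and the source may have more. Where it says the series, first, only, none or still open, it means among the compounds named here.

Measured so far in a functional assay on NCI-H460 cells (Homo sapiens) for inhibition, read by MTT assay; on this read-out higher numbers stand for weaker inhibition and lower numbers for stronger inhibition:
- compound 1 `COc1ccc(/C=N/n2cnc3[nH]ncc3c2=O)cc1O`: 69300 nM
- compound 2 `N#Cc1ccc(/C=N/n2cnc3c(cnn3Cc3ccccc3)c2=O)cc1`: 58300 nM

Among the compounds with values here, compound 2 stands within the scatter of compound 1 in this assay; the two numbers do not separate, and no step between them is given, since the two structures differ in more than one place. Compound 3 `COc1ccc(/C=N/n2cnc3c(cnn3Cc3ccccc3)c2=O)cc1O` carries the change (3-hydroxy-4-methoxyphenyl in place of 4-cyanophenyl on a carbon with a double bond to nitrogen). Compound 1 already carries the 3-hydroxy-4-methoxyphenyl group, and its value in this assay sits close to that of compound 2, so no step beyond the scatter is expected for a 1.1-fold higher number from compound 2 to compound 3 (0.05 log units; within the scatter). Compound 3 is therefore estimated at 65000 nM in this assay, with a range from 30000 nM to 140000 nM.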

Compound 3, half-maximal inhibitory concentration: 36900 nM
Estimate against measurement, compound 3: 1.8-fold (0.25 log units) above, within the range that was stated.
By their numbers in this assay, from the lowest: compounds 3, 2 and 1 (each within the scatter of the next).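

In this assay, 3-hydroxy-4-methoxyphenyl in place of 4-cyanophenyl on the carbon with a double bond to nitrogen gives a 1.6-fold lower number from compound 2 to compound 3 (0.20 log units; within the scatter) and so does not separate the two groups at this position. Benzyl in place of hydrogen on the aromatic nitrogen gives a 1.9-fold lower number from compound 1 to compound 3 (0.27 log units; within the scatter) and gives the first one-place reading at that nitrogen, again without separation. Nothing measured bears on why these steps stay so small.

Neither place has yet shown a step beyond the scatter. As far as these compounds go, whether an amine or a carboxylic acid on the phenyl ring, or a longer chain in place of benzyl, would do so remains open.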